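The compounds below may be only part of what the source reports. "The series", "measured", "known", "first", "only" and "open" are said of these compounds alone.

Measured compounds:
- compound 1 `CN(C)CCCCCSC1=Nc2ccccc2C(CC(=O)NCc2ccccc2)N1c1ccc(-c2ccc(F)cc2)cc1`: 17600 nM
- compound 2 `O=C(CC1c2ccccc2N=C(SCCCCCN2CCCC2)N1c1ccc(-c2ccccc2)cc1)NCc1ccc(F)cc1`: 19800 nM
- compound 3 `CN(C)CCCCCSC1=Nc2ccccc2C(CC(=O)NCc2ccccc2)N1c1ccc(-c2ccccc2)cc1`: 18100 nM

In a functional assay on A549 cells (Homo sapiens) for cytotoxicity, read by MTT assay, with a stated time of 48 h (on this read-out lower numbers stand for stronger inhibition and higher numbers for weaker inhibition), compound 3 stands at the second highest of the three numbers. Its nearest neighbour is compound 1, which gives 17600 nM, and its furthest is compound 2, which gives 19800 nM; both gaps lie within the scatter, so no order among the three can be read.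

Compound 4 `CN(C)CCCCCSC1=Nc2ccccc2C(CC(=O)NCc2ccc(F)cc2)N1c1ccc(-c2ccccc2)cc1` is reached from compound 3 by one change: fluoro in place of hydrogen on an aromatic carbon. Going by the values given here, only one measured step bears directly on such a swap of fluoro for hydrogen on an aromatic carbon, and it runs the other way: a 1.0-fold higher number from compound 1 to compound 3 (0.01 log units; within the scatter). Among the compounds with values here, compound 2 also carries the 4-fluorobenzyl group, but it differs from compound 3 in a second place as well, so its value alone cannot be split into the two changes; it shows only that the number stays in the same region. On this evidence the step is expected to be none beyond the scatter: a 1.0-fold higher number from compound 3 to compound 4 (0.01 log units; within the scatter). Compound 4 is therefore estimated at 18500 nM, with a range from 10000 nM to 34000 nM.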

Compound 4, half-maximal inhibitory concentration: 5000 nM
Estimate against measurement, compound 4: 3.7-fold (0.57 log units) above, and the stated range ends above it.
By their numbers in this assay, from the lowest: compound 4; then compounds 1, 3 and 2 (each within the scatter of the next).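

Moving the fluoro to the benzyl group on the amide gives a change that the earlier compounds did not show: in this assay, benzyl to 4-fluorobenzyl produces a step beyond the scatter (a 3.6-fold lower number from compound 3 to compound 4 (0.56 log units; beyond the scatter)), whereas removing the fluoro from the phenyl ring of compound 1 produces none (a 1.0-fold higher number from compound 1 to compound 3 (0.01 log units; within the scatter)), so among these compounds the same swap has a different outcome on a different ring. The 4-fluorobenzyl group does not bring the lower number alone, since with this group held constant the amine at the end of the chain also matters, with dimethylamino in place of pyrrolidin-1-yl again giving a step beyond the scatter (a 4.0-fold lower number from compound 2 to compound 4 (0.60 log units; beyond the scatter)). Both steps are modest, and nothing available here accounts for either of them.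

The compounds shown leave open whether a chloro or methoxy group on the benzyl ring would give a similar step, and whether fluoro is needed there at all. They also leave open how far the amine can vary, for example with piperidin-1-yl or diethylamino at the end of the chain, and whether a shorter chain would keep the number of compound 4.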